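The compounds below may be only part of what the source reports. "The series", "measured", "known", "first", "only" and "open" are said of these compounds alone.

Compound 1, `C#CCSc1nc(NCCC(C)C)c2ccncc2n1`: in a functional assay on PC-3 cells (Homo sapiens) for inhibition, read by MTT assay, with a stated time of 72 h (a lower number here means a stronger inhibitor, a higher number a weaker inhibitor), compound 1 reaches only the limit > 80000 nM.
Compound 2, `C#CCSc1nc(Nc2cccc(Cl)c2)c2ccncc2n1`: in this assay compound 2 gives 56500 nM.

Going by the values given here, compound 2 holds the only real number here; the other value is a limit of this assay, at which compound 1 sits (the limit of > 80000 nM in this assay, at which 1 of the 2 values shown sits). Among the compounds with values here, the single measured step, an at least 1.4-fold lower number from compound 1 to compound 2 (0.15 log units; that floor lies within the scatter), exchanged an isopentyl for a 3-chlorophenyl, and its floor lies within the usual scatter, so it gives little guidance on size.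

Compound 3, `C#CCSc1nc(Nc2ccc(Br)cc2)c2ccncc2n1`, differs from compound 2 by 4-bromophenyl in place of 3-chlorophenyl on a nitrogen on an aromatic ring. No measured step exchanges one halogen-bearing phenyl for another, so nothing shown points to a change beyond the scatter, and the number for compound 3 is expected to stay close to that of compound 2, with a 1.1-fold lower number from compound 2 to compound 3 (0.05 log units; within the scatter) as the expected step. Compound 3 is therefore estimated at 50000 nM in this assay, within 15000 nM to 160000 nM.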

Compound 3, half-maximal inhibitory concentration: 26000 nM
Beside the measured number, compound 3's estimate is 1.9-fold (0.28 log units) above it; the range from low to high includes it.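

Going by these compounds alone, the swap on this nitrogen is the first change between two aromatic groups, and it moves the number beyond the scatter in this assay, with a 2.2-fold lower number from compound 2 to compound 3 (0.34 log units; beyond the scatter). Replacing isopentyl with an aromatic group now also gives a clear change, with an at least 3.0-fold lower number from compound 1 to compound 3 (0.48 log units; beyond the scatter), which the 3-chlorophenyl step could not establish. That step gives only a floor for the size of the change, because compound 1 has a limit rather than a real number: the limit of > 80000 nM in this assay, at which 1 of the 3 values shown sits.

The halogen and its place on the ring changed together, so the compounds shown cannot separate the two; 4-chlorophenyl or 3-bromophenyl would be needed to do that. As far as these compounds go, it also remains open how an unsubstituted phenyl, or a phenyl carrying a methoxy group or an amine, would compare in this assay.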